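A few compounds are considered here, and "the series" means these few. Any claim that something is new, unique, unknown or untested is made for them only; others in the source may bear on it.

In an ADME assay on CCRF-HSB-2 cells (Homo sapiens) for cytotoxicity, with a stated time of 7 days (a lower number here means that less compound is tolerated, a higher number that more compound is tolerated), compound 3 `CN(C)c1nc(N)nc2c1ncn2/C=C1/CC1(CO)CO` reads > 20000 nM, which is a limit and not a number. Compound 1 `C=CCOc1nc(N)nc2c1ncn2/C=C1/CC1(CO)CO` reads > 20000 nM, also a limit. Compound 2 `CCCCCCCCOc1nc(N)nc2c1ncn2/C=C1/CC1(CO)CO` reads > 20000 nM, again a limit. The record so far therefore comes down to the limit of > 20000 nM in this assay, at which 3 of the 3 values shown sit.

Compound 4 `Nc1nc(OCc2ccccc2)c2ncn(/C=C3/CC3(CO)CO)c2n1` differs from compound 3 by benzyloxy in place of dimethylamino on an aromatic carbon. Two measured steps involve the same place, a step that the two limits leave unreadable from compound 1 to compound 3 and a step that the two limits leave unreadable from compound 2 to compound 3, and the step that the two limits leave unreadable from compound 1 to compound 2 compares allyloxy with octyloxy there. None of the three has a readable size. They offer no sign of a change in either direction, although they cannot rule one out. Allyloxy, octyloxy and dimethylamino all leave the read-out at the limit of > 20000 nM in this assay, at which 3 of the 3 values shown sit, so compound 4 is expected to stay at or near that limit in this assay, with no step beyond the scatter. The expected size is a step that the limit leaves unreadable from compound 3 to compound 4. For compound 4 the estimated value is 25000 nM, within an expected range of 10000 nM to 60000 nM.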

Compound 4, half-maximal cytotoxic concentration: > 20000 nM
Compound 4: no number, only a limit (the forecaster's own chance of this, stated with the estimate: 85%); the middle value lies beyond the limit too.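

Compound 4 reads > 20000 nM in this assay, which is a limit and not a number, so none of its steps from compound 1, compound 2 or compound 3 can be read. The compounds shown leave open whether these groups on the shared core differ at all in how much compound is tolerated, since every reading ends at the same point: the limit of > 20000 nM in this assay, at which 4 of the 4 values shown sit.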